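Swapping the piperazine amide for an aminopropyl methylpiperazine

The source may report more compounds than this note shows. Statements on the series, on what has been measured and on what is new or still open speak of the compounds shown alone.

Compound 2 `NC(=O)CN1CCN(c2nc(-c3cccnc3)nc3c2CN(Cc2ccccc2)CC3)CC1` gives 100000 nM in an assay on cells with Cystic fibrosis transmembrane conductance regulator variant F508del (Homo sapiens) as the target, read by fluorescence, with stated times of 24 h and 30 min (a lower number here means that less compound is needed, a higher number that more compound is needed for the effect), level with compound 1 `NC(=O)C1CCN(c2nc(-c3cccnc3)nc3c2CN(Cc2ccccc2)CC3)CC1` at 100000 nM, and together these are the highest numbers of the three measured; compound 3 `C=CCc1cc(-c2sc(NC(=O)C(C)(C)C)nc2C)nn1C(=O)Nc1ccc(OC)cc1`, built on a different scaffold, gives 933 nM. Compound 4 `CN1CCN(CCCNc2nc(-c3cccnc3)nc3c2CN(Cc2ccccc2)CC3)CC1` differs from compound 2 by (3-(4-methylpiperazin-1-yl)propyl)amino in place of 4-(carbamoylmethyl)piperazin-1-yl on an aromatic carbon. Among the compounds with values here, only one measured step bears on this change: no change at the digits printed from compound 1 to compound 2 (within the scatter), where one amide-bearing ring replaced another without effect. Within the data shown here, no measured step tests a change of this kind, so compound 4 is expected to stay near compound 2, with a 1.7-fold lower number from compound 2 to compound 4 (0.22 log units; within the scatter) the estimated step. Compound 4 is therefore estimated at 60000 nM, within a range from 10000 nM to 100000 nM.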

Compound 4, half-maximal effective concentration: 100000 nM
For compound 4 the middle estimate is 1.7-fold (0.22 log units) below the measured one; measured number inside the range.
By their numbers in this assay, from the lowest: compound 3; then compounds 1, 2 and 4 (each within the scatter of the next).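

In this assay, the change at this aromatic carbon now reaches beyond amide-bearing rings: with (3-(4-methylpiperazin-1-yl)propyl)amino in place, there is no change at the digits printed from compound 2 to compound 4 (within the scatter), and likewise no change at the digits printed from compound 1 to compound 4 (within the scatter). So compound 4, which swaps the carbamoyl group for a methylpiperazine at the end of a propyl chain joined through an amino group, sits level with both earlier compounds. Nothing available explains this lack of change. Still open, as far as these compounds go, is whether a much smaller group here, such as a methoxy or a plain amine, would lower the number. A carboxylic acid on the piperidine ring is equally untested by the compounds shown.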